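This account rests on a few compounds, and the source may have more. Where it says the series, first, only, none or still open, it means among the compounds named here.

Measured so far in an in vitro functional assay on cells for agonist activity at Bombesin receptor subtype-3 (Mus musculus), read by luminescence and calcium flux; on this read-out lower numbers stand for an effect already at smaller amounts and higher numbers for an effect only at larger amounts of compound:

Compound 1, `CCC(C)(C)Cc1c[nH]c(CCc2ccc(-c3ccccc3C(=O)O)cc2)n1`, gives 9.6 nM.
Compound 2, `N#Cc1ccc(Cc2cnc(CCc3ccc(-c4ccccc4C(=O)O)cc3)[nH]2)cc1`, gives 723 nM.
Compound 3, `CCCCc1cnc(C(CCCO)Cc2ccc(-c3ccccc3C(=O)O)cc2)[nH]1`, gives 238 nM.

Among these three, compound 2 stands at the highest number, so it needs the largest amount of compound for a half-maximal effect. Compound 3 is its nearest neighbour, and the gap between them lies beyond the usual scatter. Compound 1 is furthest away, with by far the lowest number of the set.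

The next compound, compound 4, `COc1ccccc1Cc1cnc(CCc2ccc(-c3ccccc3C(=O)O)cc2)[nH]1`, has not yet been measured in this assay. It differs from compound 2 in one place: 2-methoxyphenyl in place of 4-cyanophenyl on a saturated chain carbon bound to an aromatic carbon. Among the compounds with values here, the three measured compounds do not include any pair that differs only in this way, so there is no directly comparable step to lean on. Since the shared core and the link to it stay unchanged, a modest step is expected, most likely towards a lower number, but one that may well stay within the scatter. Compound 4 is therefore estimated at 400 nM, within a range from 100 nM to 1500 nM. This estimate corresponds to an expected step of a 1.8-fold lower number from compound 2 to compound 4 (0.26 log units; within the scatter).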

Compound 4, half-maximal effective concentration: 163 nM
For compound 4 the middle estimate is 2.5-fold (0.39 log units) above the measured one; measured number inside the range.
By their numbers in this assay, from the lowest: compound 1; then compounds 4 and 3 (each within the scatter of the next); then compound 2.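

Within the data shown here, the change from 4-cyanophenyl to 2-methoxyphenyl on this saturated chain carbon is the first single-place step available in this assay, and it gives a 4.4-fold lower number from compound 2 to compound 4 (0.65 log units; beyond the scatter). This shows that the number responds to what the aromatic ring at this position carries, even though the two groups match in heavy-atom count, with one six-membered aromatic ring, no hydrogen-bond donors and one hydrogen-bond acceptor each. Nothing available explains the size or direction of this step.

Since both the group and its place on the ring change together, this one pair leaves open whether removing the nitrile or adding the methoxy group accounts for the lower number. Plain phenyl or 4-methoxyphenyl at this position would help separate the two, while an amine on the ring remains untested territory here.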